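Aryl ring changes in a prostaglandin D2 receptor 2 series

The compounds below may be only part of what the source reports. "The series", "measured", "known", "first", "only" and "open" are said of these compounds alone.

Measured compounds, all in an in vitro functional assay on HEK285-7 cells for antagonist activity at prostaglandin D2 receptor 2 (Homo sapiens), read by BRET and beta-arrestin recruitment; a higher number here means a weaker inhibitor, a lower number a stronger inhibitor:
compound 1 `O=C(O)Cc1sc(C(c2ccc(F)cc2)c2ccc(F)cc2)nc1-c1cccc(F)c1`: 18 nM
compound 2 `N#Cc1cc(-c2nc(C(c3ccc(F)cc3)c3ccc(F)cc3)sc2CC(=O)O)ccc1F`: 520 nM
compound 3 `O=C(O)Cc1sc(C(c2ccc(F)cc2)c2ccc(F)cc2)nc1-c1cc(F)nc(F)c1`: 110 nM

Compound 3 sits second highest of the three numbers in this assay; it is separated from compound 2 by a 4.7-fold lower number from compound 2 to compound 3 (0.67 log units; beyond the scatter) and from compound 1 by a 6.1-fold higher number from compound 1 to compound 3 (0.79 log units; beyond the scatter), both beyond the scatter.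

Compound 4 `Nc1cc(-c2nc(C(c3ccc(F)cc3)c3ccc(F)cc3)sc2CC(=O)O)cc(F)n1` differs from compound 3 at one place: amino in place of fluoro on an aromatic carbon. For the measured compounds named here, no measured pair shows a fluoro-to-amino exchange, so the bearing steps are only the ones that vary the aryl ring as a whole: a 29-fold higher number from compound 1 to compound 2 (1.46 log units; beyond the scatter), a 6.1-fold higher number from compound 1 to compound 3 (0.79 log units; beyond the scatter) and a 4.7-fold lower number from compound 2 to compound 3 (0.67 log units; beyond the scatter). Those show that changes on this ring move the number by modest to large amounts in either direction. Going by the values given here, with no closer precedent, compound 4 is expected to stay near compound 3, with a step of a 1.5-fold higher number from compound 3 to compound 4 (0.16 log units; within the scatter), and a modest loss is thought slightly more likely than a gain. Compound 4 is estimated at 160 nM in this assay, within a range from 40 nM to 600 nM.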

Compound 4, half-maximal inhibitory concentration: 1400 nM
Compound 4: the middle estimate sits 8.8-fold (0.94 log units) below what was measured; the measured number lies above the stated range.
By their numbers in this assay, from the lowest: compound 1; then compound 3; then compound 2; then compound 4.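

In this assay, the fluoro next to the ring nitrogen does not accept amino as a neutral exchange: the change of one heavy atom gives a 13-fold higher number from compound 3 to compound 4 (1.10 log units; beyond the scatter), a large step at a single position. The 2-amino-6-fluoropyridin-4-yl ring also falls behind the 3-cyano-4-fluorophenyl ring, with a 2.7-fold higher number from compound 2 to compound 4 (0.43 log units; beyond the scatter), and further behind the 3-fluorophenyl ring, with a 78-fold higher number from compound 1 to compound 4 (1.89 log units; beyond the scatter), which makes compound 4 the weakest of the four. Nothing on hand explains this loss.

Still open, on these data alone, is whether the loss follows from the arrival of amino or from the departure of fluoro at this carbon. A plain hydrogen, a methyl, a methoxy or a dimethylamino group at the same place would help separate the two readings.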